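Second Chlorine on the Benzyl Ring of a Pyridyl Benzamide

The compounds below may be only part of what the source reports. "The series", "measured", "known", "first", "only" and "open" are said of these compounds alone.

Of the compounds shown here, two of one series have been measured in an assay on lysate for inhibition of phosphatidylcholine:ceramide cholinephosphotransferase 2 (Homo sapiens), read by HPLC, with stated times of 30 min and 2 h; a higher number here means a weaker inhibitor, a lower number a stronger inhibitor. Compound 1 `O=C(Nc1cccnc1)c1ccccc1OCc1cccc(F)c1` gives 1600 nM in this assay. Compound 2 `O=C(Nc1cccnc1)c1ccccc1OCc1cc(F)ccc1Cl` gives 740 nM in this assay, which is the lowest of the two numbers shown; the only step that leads to it is a 2.2-fold lower number from compound 1 to compound 2 (0.33 log units; beyond the scatter), a modest move that lies beyond the scatter.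

Compound 3 `O=C(Nc1cccnc1)c1ccccc1OCc1c(Cl)cccc1Cl` has not yet been measured. It differs from compound 2 in one place: 2,6-dichlorophenyl in place of 2-chloro-5-fluorophenyl on a saturated chain carbon bound to an oxygen on an aromatic ring. Among the measured compounds shown here, the one step at hand, from compound 1 to compound 2, bears on it only in part, since it adds a chlorine while keeping the fluorine, whereas here the fluorine is given up and a second chlorine enters. Nothing measured shows what removing that fluorine does. On the strength of the step from compound 1 to compound 2, a small further drop is expected, a 1.5-fold lower number from compound 2 to compound 3 (0.17 log units; within the scatter), though a result within the scatter would not surprise. For compound 3 the estimated value in this assay is 500 nM, with a range from 200 nM to 1500 nM.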

Compound 3, half-maximal inhibitory concentration: 690 nM
For compound 3 the middle estimate is 1.4-fold (0.14 log units) below the measured one, and the stated range covers the measured number.
By their numbers in this assay, from the lowest: compounds 3 and 2 (each within the scatter of the next); then compound 1.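

In this assay, 2,6-dichlorophenyl in place of 2-chloro-5-fluorophenyl on a saturated chain carbon bound to an oxygen on an aromatic ring gives a 1.1-fold lower number from compound 2 to compound 3 (0.03 log units; within the scatter), so the two groups cannot be told apart at this position. Compound 2 had shown only that adding a chlorine while keeping the fluorine lowers the number; compound 3 shows that the fluorine can leave, with a second chlorine entering, and the result stays within the scatter of compound 2. Against the 3-fluorophenyl group of compound 1, the 2,6-dichlorophenyl group gives a 2.3-fold lower number from compound 1 to compound 3 (0.37 log units; beyond the scatter), a second modest step beyond the scatter, so two different chlorine-bearing groups now stand apart from compound 1. Nothing given here explains why the two chlorine-bearing groups read alike.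

The compounds shown leave open how much of this comes from a single chlorine, since 2-chlorophenyl, carrying neither fluorine nor a second chlorine, is not among them. They also leave open whether groups such as 2,6-dimethylphenyl or 2,6-dibromophenyl would fit this position as well, or whether an amine or a carboxylic acid on this ring would change the number.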